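Bile acid receptor agonists: aryl replacement on the pendant phenyl

The compounds below may be only part of what the source reports. "The series", "measured", "known", "first", "only" and "open" are said of these compounds alone.

Measured compounds:
- compound 1 `Cc1ccccc1-n1nc(C)c2c1NC(=O)[C@H](C)S[C@@H]2c1ccc(-c2cccc(C(=O)O)c2)cc1`: "not active" (no number reported)
- compound 2 `Cc1ccccc1-n1nc(C)c2c1NC(=O)[C@H](C)S[C@@H]2c1ccc(-c2ccoc2)cc1`: 3500 nM
- compound 3 `COC(=O)c1cccc(-c2ccc([C@H]3S[C@@H](C)C(=O)Nc4c3c(C)nn4-c3ccccc3C)cc2)c1`: "not active" (no number reported)

In an assay on isolated protein for agonist activity at Bile acid receptor (Homo sapiens), read by AlphaScreen, with a stated time of 30 min (a higher number here means that more compound is needed for the effect, a lower number that less compound is needed), compound 3 stands without a single number, one of two entries in the set reported only as inactive; the other is compound 1, which in this assay also gives "not active" (no number reported). Only compound 2 gives a number, 3500 nM in this assay.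

Compound 4 `COc1ccccc1-c1ccc([C@H]2S[C@@H](C)C(=O)Nc3c2c(C)nn3-c2ccccc2C)cc1` differs from compound 3 as follows: 2-methoxyphenyl in place of 3-(methoxycarbonyl)phenyl on an aromatic carbon

Since compound 3 carries no number in this assay, no step size can be stated; the expectation is that compound 4 moves into the measurable range, in the direction of less compound needed. For compound 4 a value near 4000 nM is estimated, within 1000 nM to 20000 nM.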

Compound 4, half-maximal effective concentration: 1100 nM
For compound 4 the middle estimate is 3.6-fold (0.56 log units) above the measured one, and the stated range covers the measured number.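

In this assay this place on the pendant phenyl accepts a substituted phenyl ring: compound 4, with 2-methoxyphenyl, gives 1100 nM and compound 3, with 3-(methoxycarbonyl)phenyl, gives "not active" (no number reported) in the same assay. The change from furan-3-yl to 2-methoxyphenyl gives a 3.2-fold lower number from compound 2 to compound 4 (0.50 log units; beyond the scatter) and shows that a measurable value here is not confined to furan-3-yl. Nothing available accounts for the difference between these groups. Left open is how a plain phenyl or an aminophenyl group would compare with 2-methoxyphenyl at this place.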